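The source may hold more compounds than are shown below. What is called first, only, known or untested is meant among the compounds shown, and "the series" means these compounds.

Compound 1 `Cc1ccc(C2=NN(c3nc(-c4ccc(F)cc4)cs3)C(c3ccc(F)cc3)C2)s1` and compound 2 `Cc1ccc(C2=NN(c3nc(-c4ccc(C(F)(F)F)cc4)cs3)C(c3ccc(F)cc3)C2)s1` share one core and differ only on the aromatic ring attached to the thiazole. In a functional assay on A549 cells (Homo sapiens) for antiproliferative activity, read by XTT assay, with a stated time of 24 h (a higher number here means a weaker inhibitor, a lower number a stronger inhibitor), compound 1 gives 125 ug/mL. Compound 2 reaches only the limit of this assay, > 500 ug/mL, so for compound 2 the number is a limit and not a value. The step of an at least 4.0-fold higher number from compound 1 to compound 2 (0.60 log units; beyond the scatter) is beyond the scatter; one of the two values shown sits at the limit of > 500 ug/mL in this assay, at which 1 of the 2 values shown sits, so compound 2 stands at the weak end of what has been measured.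

Compound 3 `Cc1ccc(C2=NN(c3nc(-c4ccc(Cl)cc4)cs3)C(c3ccc(F)cc3)C2)s1` is the next member. It differs from compound 2 by chloro in place of trifluoromethyl on an aromatic carbon. Among the compounds with values here, the only measured step that bears on this change is the one from compound 1 to compound 2, where trifluoromethyl in place of fluoro gave an at least modest rise in the number. Chloro sits between those two groups in what it brings to the ring, so a step back toward the number of compound 1 is expected, an at least 2.0-fold lower number from compound 2 to compound 3 (0.30 log units; that floor lies within the scatter), with wide uncertainty. The estimate for compound 3 in this assay is 250 ug/mL, between 100 ug/mL and 600 ug/mL.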

Compound 3, half-maximal inhibitory concentration: > 500 ug/mL
Compound 3 was reported as a limit (the forecaster's own chance of this, stated with the estimate: 30%); at least 2.0-fold (0.30 log units) between middle value and limit.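

Chloro in place of fluoro on this aromatic carbon gives an at least 4.0-fold higher number from compound 1 to compound 3 (0.60 log units; beyond the scatter), so the rise in the number seen earlier is no longer tied to trifluoromethyl alone: both replacements of fluoro shown here move the number the same way. Compound 2 and compound 3 each stand only as a limit, and the step between them cannot be read, so chloro and trifluoromethyl cannot be put in order in this assay. Of the three compounds, only compound 1 now has a measured number, and the other two share one ceiling: the limit of > 500 ug/mL in this assay, at which 2 of the 3 values shown sit.

From the compounds shown here alone, how far the true values of compound 2 and compound 3 lie past that limit stays open, and so does whether the higher number follows from leaving fluoro or from the particular groups that replaced it. Nothing shown tells how a methoxy group, an amine or a carboxylic acid on this aromatic carbon would read in this assay, or whether any of them would give a number lower than that of compound 1.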